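Nitro on the Furan Ring: One Change Made Twice

The source may report more compounds than this note shows. Statements on the series, on what has been measured and on what is new or still open speak of the compounds shown alone.

Compound 1, `COc1ccc(Cc2nnc3n2NC(c2ccco2)S3)cc1OC`, gives 12% in a functional assay on the whole organism (strain Wistar Albino) for inhibition, with Rattus norvegicus as the target, read by paw edema, with a stated time of 1 h, at a dose of 20 mg/kg; on this read-out higher numbers stand for more inhibition at the one dose given (going by the name of the read-out) and lower numbers for less inhibition. Compound 2, `Cc1occc1-c1nnc2n1NC(c1ccco1)S2`, gives 16.4% in this assay. Compound 3, `COc1ccc(Cc2nnc3n2NC(c2ccc([N+](=O)[O-])o2)S3)cc1OC`, gives 14.5% in this assay.

The three measured compounds share a core and differ in what hangs from it. Compound 1 and compound 2 carry different groups on that core; the difference between these two cores is not broken down here. Compound 3 is compound 1 with one change, (nitro in place of hydrogen on an aromatic carbon), and that change made a number 2.5 percentage points higher from compound 1 to compound 3 (within the scatter). Of the three, compound 2 has the highest reading, yet its distance to compound 3 and to compound 1 lies within the scatter, so no order can be claimed among them.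

Compound 4, `Cc1occc1-c1nnc2n1NC(c1ccc([N+](=O)[O-])o1)S2`, is the unmeasured member. It stands to compound 2 as compound 3 stands to compound 1: the change is nitro in place of hydrogen on an aromatic carbon, the same change as before, at the same place on the furan ring. Within the data shown here, the only guide to its effect is the pair compound 1 and compound 3, where the step stayed within the scatter.

On that basis the step from compound 2 to compound 4 is expected to be a number 2.1 percentage points higher from compound 2 to compound 4 (within the scatter) in this assay, a small shift that rests on a number 2.5 percentage points higher from compound 1 to compound 3 (within the scatter). Compound 4 is therefore estimated to give 18.5% in this assay, with a likely range from 9% to 28%.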

Compound 4, a percentage reported as inhibition, in the whole organism at one dose (the size of the read-out at that dose, not a potency): 15.6%
For compound 4 the middle estimate is 2.9 percentage points above the measured one; the measured number falls inside the stated range.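

In this assay, putting nitro in place of hydrogen on an aromatic carbon of the five-membered aromatic ring with 1 oxygen gave a number 0.8 percentage points lower from compound 2 to compound 4 (within the scatter), so on this second core too the change left no reading that can be told from the scatter. Set side by side, the two steps do not differ, and the comparison reads: the same change on two cores in this assay, a number 2.5 percentage points higher (within the scatter) from compound 1 to compound 3 and a number 0.8 percentage points lower (within the scatter) from compound 2 to compound 4, 3.3 percentage points apart, within the scatter of two such steps. This shows that, across these two pairs, the change stayed within the scatter on both cores and that the core did not visibly alter the outcome, but it does not show that the change has no effect, that its effect is the same on both cores, or that the same result would hold on any other core in this series, since steps this small leave room for a real but modest effect on either core.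

What the compounds shown leave open is whether any group at this place on the ring would move the reading beyond the scatter, for instance an amine or a carboxylic acid in place of nitro. As far as these compounds go, it also remains open whether a longer chain on the other side of the shared core would change how nitro behaves there.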